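The source may report more compounds than this note shows. Statements on the series, on what has been measured and on what is new or still open speak of the compounds shown alone.

Measured in a functional assay on MCF7 cells (Homo sapiens) for antiproliferative activity, read by WST assay, with a stated time of 5 days; a higher number here means a weaker inhibitor, a lower number a stronger inhibitor:
- compound 1 `COc1cc(O)c2c(c1O)C/C(C)=C\CC[C@@]1(C)O[C@@H]1C2=O`: 15000 nM
- compound 2 `COc1cc(O)c2c(c1O)[C@@H](O)/C(C)=C\CC[C@@]1(C)O[C@@H]1C2=O`: 6200 nM
- compound 3 `COc1cc(O)c2c(c1O)C/C(CO)=C\CC[C@@]1(C)O[C@@H]1C2=O`: 43000 nM

Of these three, compound 3 has the highest number, 43000 nM, and is therefore the weakest inhibitor. Compound 4 `COc1cc(O)c2c(c1O)C/C(CBr)=C\CC[C@@]1(C)O[C@@H]1C2=O` keeps the shared core and differs from it in one group: bromo in place of hydroxy on a saturated chain carbon bound to a double-bonded ring carbon. In short, hydroxymethyl becomes bromomethyl.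

The most relevant evidence comes from the same place, where hydroxy replaces hydrogen: a 2.9-fold higher number from compound 1 to compound 3 (0.46 log units; beyond the scatter). The other measured step, a 2.4-fold lower number from compound 1 to compound 2 (0.38 log units; beyond the scatter), is also modest, but it lies on a saturated ring carbon and bears on this change less directly. Among the measured compounds shown here, no measured compound carries bromo, so any transfer is uncertain. Even so, removing the hydroxy may reverse the rise seen for compound 3, so a modest move to a lower number is expected in this assay. The estimated change is a 3.6-fold lower number from compound 3 to compound 4 (0.55 log units; beyond the scatter). For compound 4 the expected value is 12000 nM, with an estimated range of 3000 nM to 35000 nM.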

Compound 4, half-maximal inhibitory concentration: 32000 nM
Compound 4: the middle estimate sits 2.7-fold (0.43 log units) below what was measured, within the range that was stated.
By their numbers in this assay, from the lowest: compound 2; then compound 1; then compounds 4 and 3 (each within the scatter of the next).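

In this assay the change from hydroxymethyl to bromomethyl gives a 1.3-fold lower number from compound 3 to compound 4 (0.13 log units; within the scatter) and so does not separate the two groups at this place. Bromo in place of hydrogen gives a 2.1-fold higher number from compound 1 to compound 4 (0.33 log units; beyond the scatter) and hydroxy in place of hydrogen gives a 2.9-fold higher number from compound 1 to compound 3 (0.46 log units; beyond the scatter) so both groups tried on this saturated chain carbon bound to a double-bonded ring carbon carry a higher number than the hydrogen of compound 1. Nothing available accounts for this result.

The compounds shown leave open whether an amine, a carboxylic acid or a longer chain on this carbon would match hydroxy and bromo or reach a number as low as that of compound 1. They also leave open how the hydroxy on the saturated ring carbon of compound 2 would combine with a change on this chain carbon.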